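Removing the hydroxy group from compound 2

The source may hold more compounds than are shown below. What is called first, only, known or untested is meant among the compounds shown, and "the series" means these compounds.

Measured so far in a physicochemical assay for solubility, read by spectrophotometry, in phosphate buffer, measured as kinetic solubility, with a stated time of 18 h, at pH 7.4 (a higher number here means a more soluble compound, a lower number a less soluble compound), are two compounds:
- Compound 1 `Cc1ccc(-c2nc3ccccc3s2)cc1NC(=O)c1cc([N+](=O)[O-])c(N(C)C)cc1Cl` gives 30 nM
- Compound 2 `O=C(Nc1cccc(-c2nc3ccccc3s2)c1)c1cc([N+](=O)[O-])c(O)cc1Cl` gives 2200 nM

Compound 2 stands highest of the two and compound 1 lies lower, a gap beyond the scatter. Compound 3 `O=C(Nc1cccc(-c2nc3ccccc3s2)c1)c1cc([N+](=O)[O-])ccc1Cl` has hydrogen in place of hydroxy on an aromatic carbon of compound 2 hydrogen in place of hydroxy on an aromatic carbon and is still to be measured. A fall beyond the scatter is expected in this assay. Among the measured compounds shown here, the evidence is compound 1 at 30 nM as the one measured compound without hydroxy, though it also differs elsewhere. The estimated change is a 7.3-fold lower number from compound 2 to compound 3 (0.87 log units; beyond the scatter) as a moderate drop. Compound 3 is expected at 300 nM within an estimated range of 60 nM to 1200 nM in this assay read-out.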

Compound 3, solubility: 580 nM
Compound 3: the middle estimate sits 1.9-fold (0.29 log units) below what was measured; low and high end bracket the measured number.
By their numbers in this assay, from the lowest: compound 1; then compound 3; then compound 2.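

In this assay, hydrogen in place of hydroxy on this aromatic carbon, ortho to a nitro group and para to a large group, gives a 3.8-fold lower number from compound 2 to compound 3 (0.58 log units; beyond the scatter) and nothing else changes. Among the compounds shown here, this is the first step that rests on one change alone, and it is a modest one. No measurement shown gives a reason for this step. Still open, from the compounds shown here alone, is where a methoxy group, a primary amine or a carboxylic acid on this carbon would fall. Also open, going by these compounds, is whether the same step holds with the other changes present in compound 1.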